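The source may hold more compounds than are shown below. What is called first, only, known or untested is meant among the compounds shown, and "the series" means these compounds.

In an assay on isolated protein for inhibition of Nitric oxide synthase, inducible (Homo sapiens), with a stated time of 30 min (a higher number here means a weaker inhibitor, a lower number a stronger inhibitor), the measured compounds stand as follows:
Compound 1 `C/C=C/c1cc(C)cc(N)n1` gives 282 nM.
Compound 3 `Cc1cc(N)nc(CCCCF)c1` gives 170 nM.
Compound 2 `Cc1cc(N)nc(CC(C)OCCF)c1` gives only a limit of the assay, > 5000 nM.

Within the data shown here, compound 2 is thus the one compound for which no number is known; what is known of it is the limit of > 5000 nM in this assay, at which 1 of the 3 values shown sits. Compounds 1 and 3 show numbers that lie within the scatter of each other. Compound 4 `CSCCC(C)Cc1cc(C)cc(N)n1` differs from compound 2 by one change: 2-(methylsulfanyl)ethyl in place of 2-fluoroethoxy on a saturated chain carbon bound to two saturated chain carbons. Among the measured compounds shown here, no step between two measured compounds matches this change, so any expectation for compound 4 rests only on the limit of compound 2 and on the numbers of compounds 1 and 3. Compound 4 is expected to move toward the numbers of compounds 1 and 3 without reaching them. The estimated step in this assay is an at least 2.5-fold lower number from compound 2 to compound 4 (0.39 log units; beyond the scatter). Compound 4 is expected to give about 2000 nM, within a range from 400 nM to 8000 nM, with a real chance that the assay again reports only a limit.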

Compound 4, half-maximal inhibitory concentration: > 5000 nM
Compound 4: no number, only a limit (the forecaster's own chance of this, stated with the estimate: 30%); middle value at least 2.5-fold (0.39 log units) from the limit.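

In this assay, compound 2 and compound 4 each give only a limit and not a number, and no step between them can be read: the limit of > 5000 nM in this assay, at which 2 of the 4 values shown sit.

The compounds shown leave open whether 2-(methylsulfanyl)ethyl in place of 2-fluoroethoxy changes inhibition at all.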